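A few compounds are considered here, and "the series" means these few. Any claim that something is new, unique, unknown or untested is made for them only; others in the source may bear on it.

Measured compounds:
compound 1, `Cc1nn(-c2ncnc3nc[nH]c23)c2c1C(OCc1ccccc1Cl)CC(=O)N2`: 2 nM
compound 2, `O=C1/C(=C/NCCCO)C(c2ccccc2)=NN1c1nc2ccccc2s1`: 200 nM
compound 3, `C/C(=N\NC(=O)c1cc2ccccc2cc1O)c1ccc(N)cc1`: 1100 nM

In a functional assay on HEK293 cells for agonist activity at G-protein coupled receptor 39 (Homo sapiens), read by scintillation proximity assay and inositol phosphate accumulation, with a stated time of 75 min, in the presence of a further agent that is not named here (on this read-out higher numbers stand for an effect only at larger amounts of compound and lower numbers for an effect already at smaller amounts), compound 1 gives the lowest number of the three. Compound 2 gives a higher number, and compound 3 a higher number still; both of these gaps lie beyond the usual scatter of repeated measurements, so compound 1 is the most potent of the measured set, and the two other compounds share no core with it.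

Compound 4, `Cc1nn(-c2ncnc3nc[nH]c23)c2c1C(OCc1ccc(C#N)cc1)CC(=O)N2`, keeps the core of compound 1 and differs from it in one place: 4-cyanophenyl in place of 2-chlorophenyl on a saturated chain carbon bound to an oxygen on a saturated carbon. Among the measured compounds shown here, no pair of measured compounds differing in one place is available here, so the size of this step is not anchored by a measured example.

With no such anchor, a modest loss of potency on going to compound 4 is expected, and the expected step is a 4.0-fold higher number from compound 1 to compound 4 (0.60 log units; beyond the scatter), reaching beyond the scatter but staying well short of the gap to compound 2. Compound 4 is therefore estimated at 8 nM, with a range from 2 nM to 40 nM.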

Compound 4, half-maximal effective concentration: 4 nM
Estimate against measurement, compound 4: 2.0-fold (0.30 log units) above; the range from low to high includes it.
By their numbers in this assay, from the lowest: compounds 1 and 4 (each within the scatter of the next); then compound 2; then compound 3.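

In this assay, among the compounds shown here, putting 4-cyanophenyl in place of 2-chlorophenyl on a saturated chain carbon bound to an oxygen on a saturated carbon gives a 2.0-fold higher number from compound 1 to compound 4 (0.30 log units; within the scatter), the first measured step at this position. The position thus accepts a different aryl group, with a nitrile instead of a chlorine, one more heavy atom and a hydrogen-bond acceptor, without the number moving beyond the scatter. Nothing on hand explains why the two groups read alike.

Since the substituent and its place on the ring change together in this one step, the contribution of each stays unresolved. On these data alone, it also remains open whether this position would accept an unsubstituted phenyl, or a non-aromatic group such as an amine, a carboxylic acid or a longer chain.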